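Swapping a thiazole for a methylpyrazole on the shared core

The compounds below may be only part of what the source reports. "The series", "measured", "known", "first", "only" and "open" are said of these compounds alone.

Compound 1: `c1cc(-c2nccs2)c2c(c1)C(c1ncc[nH]1)CC2`, 64%
Compound 2: `Cc1ccc2c(c1NS(C)(=O)=O)CCC2c1ncc[nH]1`, 83%
Compound 3: `Clc1ccc2c(c1-c1ccn[nH]1)CCC2c1ncc[nH]1`, 40%

All three compounds were tested in a functional assay on CHO cells for agonist activity at Alpha-1A adrenergic receptor (Homo sapiens), read by FLIPR and calcium flux; a higher number here means a larger maximal response, a lower number a smaller maximal response. Compound 1 stands second highest of the three numbers. Its nearest neighbour is compound 2, whose value of 83% lies higher by a margin beyond the scatter of repeat measurements. Furthest away is compound 3, whose value of 40% lies lower, again beyond the scatter. Within the data shown here, none of these three pairs differs in a single place, so no clean step between measured compounds is available.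

The compound still to be measured is compound 4, `Cc1n[nH]cc1-c1cccc2c1CCC2c1ncc[nH]1`. Its change from compound 1 is 3-methyl-1H-pyrazol-4-yl in place of 1,3-thiazol-2-yl on an aromatic carbon. The group that leaves and the group that enters are both five-membered aromatic rings with two hetero atoms, sitting on the same aromatic carbon of the shared core.

Among the measured compounds shown here, with no comparable step among the measured compounds, the expected size of the step from compound 1 to compound 4 in this assay is uncertain; a small decrease, or no change beyond the scatter, is expected. Compound 4 is estimated to give 58%, within a range of 35% to 80%, which corresponds to an expected step of a number 6 percentage points lower from compound 1 to compound 4 (within the scatter).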

Compound 4, largest response reached (Emax), in percent of the reference or control that the assay uses: 91%
Compound 4: the middle estimate sits 33 percentage points below what was measured; measured number above the stated range.
By their numbers in this assay, from the lowest: compound 3; then compound 1; then compounds 2 and 4 (each within the scatter of the next).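

Among these compounds, this aromatic carbon gives the first clean step in the set: in this assay, 3-methyl-1H-pyrazol-4-yl in place of 1,3-thiazol-2-yl brings a number 27 percentage points higher from compound 1 to compound 4 (beyond the scatter). The maximal response therefore depends on which group sits at this position, even though both are a five-membered aromatic ring with 2 hetero atoms and neither has a net charge. The two groups still differ in several counted ways, with 1 hydrogen-bond donor in the entering group against 0 in the leaving one, and with carbon and nitrogen in place of a ring sulfur, but no measurement is available that assigns the step to any one of these differences.

From the compounds shown here alone, it remains open whether the step belongs to the pyrazole ring or to its methyl group, a question that an unsubstituted 1H-pyrazol-4-yl group on the same carbon would help to separate. Going by these compounds, how a plain phenyl ring or an amine at this position would compare with compound 1 and compound 4 also remains open.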